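Removing the tosyl group from the phenol oxygen of compound 1

This account rests on a few compounds, and the source may have more. Where it says the series, first, only, none or still open, it means among the compounds named here.

Measured compounds:
compound 1 `Cc1ccc(S(=O)(=O)Oc2ccc3c(c2C)[C@H](Cn2cc(-c4ccc(C(F)(F)F)cc4)nn2)[C@@]24CC(=O)[C@@](C)(CC[C@@H]32)C4)cc1` — in a functional assay on SMMC-7721 cells (Homo sapiens) for cytotoxicity, read by MTT assay, with a stated time of 4 days (on this read-out lower numbers stand for stronger inhibition and higher numbers for weaker inhibition), compound 1 gives > 20000 nM, a limit of the assay.
compound 2 `Cc1ccc(S(=O)(=O)Oc2ccc3c(c2C)[C@H](Cn2cc(-c4ccc(Br)cc4)nn2)[C@@]24CC(=O)[C@@](C)(CC[C@@H]32)C4)cc1` — in this assay compound 2 gives > 20000 nM, a limit of the assay.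
compound 3 `Cc1ccc(S(=O)(=O)Oc2ccc3c(c2C)[C@H](Cn2cc(-c4ccc(F)cc4)nn2)[C@@]24CC(=O)[C@@](C)(CC[C@@H]32)C4)cc1` — in this assay compound 3 gives > 20000 nM, a limit of the assay.

Compound 1 stands at the limit of this assay; no number is known for it, and the same holds for the other two, as the limit of > 20000 nM in this assay, at which 3 of the 3 values shown sit, records. The steps among the measured compounds, a step that the two limits leave unreadable from compound 1 to compound 2, a step that the two limits leave unreadable from compound 1 to compound 3 and a step that the two limits leave unreadable from compound 2 to compound 3, all change the aryl substituent on the triazole and are unreadable, since both ends sit at a limit.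

Compound 4 `Cc1c(O)ccc2c1[C@H](Cn1cc(-c3ccc(C(F)(F)F)cc3)nn1)[C@@]13CC(=O)[C@@](C)(CC[C@@H]21)C3` differs from compound 1 at another place: hydrogen in place of (4-methylphenyl)sulfonyl on an oxygen on an aromatic ring. Among the compounds with values here, no measured step touches this position, so nothing bears on its size or direction. With compound 1 at its limit, a move of a step that the limit leaves unreadable from compound 1 to compound 4 is expected only as an estimate without a measured anchor. Compound 4 is expected to give 25000 nM, within 6000 nM to 100000 nM, and most likely again a limit.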

Compound 4, half-maximal inhibitory concentration: > 20000 nM
Compound 4 was reported as a limit; the forecaster's own chance of this, stated with the estimate: 70%; the middle value does not contradict the limit.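

No new step can be read, since compound 1 and compound 4 both sit at a limit and the change from ((4-methylphenyl)sulfonyl)oxy to hydroxy therefore has no readable size: the limit of > 20000 nM in this assay, at which 4 of the 4 values shown sit.

The compounds shown leave open whether this change or the aryl substituent on the triazole has any effect in this assay.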